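The source may hold more compounds than are shown below. What is called first, only, known or untested is meant among the compounds shown, and "the series" means these compounds.

Measured compounds in an ADME assay on A549 cells (Homo sapiens) for cytotoxicity, read by CellTiter-Glo; a higher number here means that more compound is tolerated, a lower number that less compound is tolerated:
- compound 1 `Cc1c(Cc2ccccc2)c(=O)oc2cc(OCC(O)CNc3ccc(Br)cc3)ccc12` gives > 100000 nM, which is a limit of the assay rather than a number.
- compound 2 `Cc1cc(=O)oc2cc(OCC(O)CN3CCC(C(N)=O)CC3)ccc12` gives > 100000 nM, likewise a limit.

For the measured compounds named here, compound 2 thus stands at the limit, and the one other value shown sits at the same place, as the limit of > 100000 nM in this assay, at which 2 of the 2 values shown sit, records. Compound 3 `Cc1c(Cc2ccc(C(F)(F)F)cc2)c(=O)oc2cc(OCC(O)CN3CCC(C(N)=O)CC3)ccc12` has not yet been measured in this assay; it differs from compound 2 by 4-(trifluoromethyl)benzyl in place of hydrogen on an aromatic carbon. Going by the values given here, no step between measured compounds is known here. The step of an at least 1.2-fold lower number from compound 2 to compound 3 (0.09 log units; that floor lies within the scatter) is expected to be small, toward less compound tolerated, and possibly within the scatter. Compound 3 is estimated at 80000 nM, within 25000 nM to 150000 nM, with a fair chance that only a limit is again reported.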

Compound 3, half-maximal cytotoxic concentration: 89300 nM
Beside the measured number, compound 3's estimate is 1.1-fold (0.05 log units) below it, within the range that was stated.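

In this assay, placing 4-(trifluoromethyl)benzyl on this aromatic carbon, two atoms from the ring oxygen, gives the first result here that is a number and not a limit. The step is an at least 1.1-fold lower number from compound 2 to compound 3 (0.04 log units; that floor lies within the scatter), so it shows only a floor, and a large group at this place is tolerated with no step beyond the scatter. The other values remain at the limit: the limit of > 100000 nM in this assay, at which 2 of the 3 values shown sit.

On these data alone, what a longer chain, an amine or a carboxylic acid would give at this carbon stays open. As far as these compounds go, whether the trifluoromethyl group or the benzyl part matters more also stays open.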